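This account rests on a few compounds, and the source may have more. Where it says the series, first, only, none or still open, it means among the compounds named here.

In a physicochemical assay for solubility, with a stated time of 24 h, tested at 30 mg/mL (a lower number here means a less soluble compound, a higher number a more soluble compound), three compounds have been measured. Compound 1 `Cc1cc(COc2ccc(S(=O)(=O)NCCC(=O)NO)cc2)c2ccccc2n1` gives 4100000 nM, compound 3 `Cc1cc(COc2ccc(S(=O)(=O)NC3(CC(=O)NO)CN(CCC(F)(F)F)C3)cc2)c2ccccc2n1` gives 3400000 nM, and compound 2 `Cc1cc(COc2ccc(S(=O)(=O)NC3(CC(=O)NO)CC3)cc2)c2ccccc2n1` gives 1600000 nM, the lowest of the three numbers. Compound 4 `Cc1cc(COc2ccc(S(=O)(=O)NC3(C(=O)NO)CCCC3)cc2)c2ccccc2n1` has not yet been measured. It differs from compound 2 on a sulfonamide nitrogen: a group of 9 heavy atoms (6 carbon, 1 nitrogen, 2 oxygen; one five-membered non-aromatic ring of carbon only) in place of a group of 8 heavy atoms (5 carbon, 1 nitrogen, 2 oxygen; one three-membered non-aromatic ring of carbon only), on a sulfonamide nitrogen.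

Within the data shown here, only one measured step bears directly on this change, and it involves the same sulfonamide nitrogen. That step, a 2.6-fold lower number from compound 1 to compound 2 (0.41 log units; beyond the scatter), is modest but lies beyond the scatter. It brought in the one-ring group that compound 4 now gives up. It does not establish a trend with group size, since compound 3 gives 3400000 nM and stands above compound 2 despite its different group on that nitrogen. With a single modest step as a guide and compound 3 pointing the other way, no step beyond the scatter is expected in this assay, only a slight lean towards a lower number. The estimated step is a 1.2-fold lower number from compound 2 to compound 4 (0.09 log units; within the scatter). For compound 4, the expected value is 1300000 nM, with an estimated range from 550000 nM to 3200000 nM.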

Compound 4, solubility: 200000 nM
Compound 4: middle estimate off by 6.5-fold (0.81 log units), on the high side; the whole stated range lies above it.
By their numbers in this assay, from the lowest: compound 4; then compound 2; then compounds 3 and 1 (each within the scatter of the next).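

In this assay, among these compounds, the sulfonamide nitrogen proves far more sensitive than the earlier compounds showed: replacing the three-membered carbon ring group with the five-membered one gives an 8.0-fold lower number from compound 2 to compound 4 (0.90 log units; beyond the scatter), although the group gains only one heavy atom, a carbon, and its counts of hydrogen-bond donors and acceptors and its net charge stay the same. This step is larger than the one seen on first bringing in a ring, and the full change from the ring-free group gives a 21-fold lower number from compound 1 to compound 4 (1.31 log units; beyond the scatter), so compounds 1, 2 and 4 now fall in order as the group's heavy-atom count rises, while compound 3 goes against any reading by size alone at 3400000 nM. No measurement available here explains the drop in compound 4. The compounds shown cannot separate the effect of ring size from that of the other differences in how the two ring groups are built. They also leave open whether a six-membered carbon ring would lie lower still in this assay, and whether an amine on the five-membered ring would change the number of compound 4.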